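The compounds below may be only part of what the source reports. "The series", "measured", "known", "first", "only" and "open" are said of these compounds alone.

Measured compounds:
compound 1 `Cc1cc(O)cc(-c2nn(CC#N)cc2-c2ccnc(-c3ccc(Oc4ccccc4)cc3)c2)c1` gives 4870 nM in a functional assay on KM12 cells (Homo sapiens) for inhibition, read by sulforhodamine B assay, with a stated time of 48 h; a lower number here means a stronger inhibitor of growth, a higher number a weaker inhibitor of growth
compound 2 `COc1cc(C)cc(-c2nn(CC#N)cc2-c2ccnc(-c3ccc(N(C)C)cc3)c2)c1` gives 1620 nM in this assay

Of these two numbers, compound 2 holds the lower one, and the gap to compound 1 is beyond the scatter of this assay, so compound 2 is the stronger growth inhibitor of the pair. Compound 1 and compound 2 differ in two places at once, so nothing can be read from them about the effect of either change alone.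

Compound 3 `Cc1cc(O)cc(-c2nn(CC#N)cc2-c2ccnc(-c3ccc(N(C)C)cc3)c2)c1` differs from compound 2 in one place only: hydrogen in place of methyl on an oxygen on an aromatic ring. Among the measured compounds shown here, no step between measured compounds shows what such a change does here; nothing in the two numbers bears on it. The step from compound 2 to compound 3 is therefore expected to be small in this assay, no larger than the scatter and of uncertain direction, which is what a 1.2-fold higher number from compound 2 to compound 3 (0.09 log units; within the scatter) means. On that basis compound 3 is estimated at 2000 nM, within a range from 700 nM to 6000 nM.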

Compound 3, concentration for total growth inhibition: 7660 nM
Compound 3: the middle estimate sits 3.8-fold (0.58 log units) below what was measured, and the stated range ends below it.
By their numbers in this assay, from the lowest: compound 2; then compounds 1 and 3 (each within the scatter of the next).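

In this assay, the group on this oxygen clearly counts: methoxy to hydroxy gives a 4.7-fold higher number from compound 2 to compound 3 (0.67 log units; beyond the scatter), so removing a single methyl is enough to weaken growth inhibition. With the hydroxy kept, dimethylamino in place of phenoxy on an aromatic carbon gives a 1.6-fold higher number from compound 1 to compound 3 (0.20 log units; within the scatter), so these two compounds cannot be told apart in this assay. Nothing available explains why the methyl on this oxygen matters.

From the compounds shown here alone, it remains open whether a larger group on this oxygen, such as ethoxy, would hold or improve on the methoxy result, or whether an amine or a fluorine in its place would behave more like methoxy or like hydroxy. It is also unknown whether methoxy would give a similar step in a compound carrying phenoxy rather than dimethylamino.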